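Working notes on microsomal stability across a shared core

The source may hold more compounds than are shown below. What is called first, only, known or untested is meant among the compounds shown, and "the series" means these compounds.

The series shares one core, seen in compound 1 `N#Cc1ccc(-c2cnc(N)c(-c3ccc(N)nc3)n2)cc1`, compound 2 `Nc1ccc(-c2cnc(N)c(-c3ccc(N)nc3)n2)cn1` and compound 3 `Nc1ncc(-c2ccc(C(=O)N3CCC(O)CC3)cc2)nc1-c1ccc(C(F)(F)F)cc1`. The measure throughout is an ADME assay on microsomes from liver (Homo sapiens) for metabolic stability, read by LC-MS, using NADPH, with a stated time of 30 min, tested at 0.1 uM, in the presence of a further agent that is not named here; a higher number here means that more of the compound is left, a lower number that less of the compound is left. In this assay compound 1 returns only a limit, > 90%. Compound 2 likewise returns only a limit in this assay, > 90%. Compound 3 too sits at a limit in this assay, > 90%. Compound 3 therefore stands exactly where the other two stand, at the limit of > 90% in this assay, at which 3 of the 3 values shown sit, and no ranking among the three can be drawn from these values. Among the measured compounds shown here, no pair of measured compounds differs in a single place, so no measured step is available.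

Compound 4 `NC(=O)c1ccc(-c2cnc(N)c(-c3ccc(C(F)(F)F)cc3)n2)cc1` is not yet measured in this assay. It differs from compound 3 by amino in place of 4-hydroxypiperidin-1-yl on a carbonyl carbon. On the evidence of compound 3 at > 90% and of every other value resting at the same limit, the step from compound 3 to compound 4 is expected to stay within the usual scatter, with no direction, as a step that the limit leaves unreadable from compound 3 to compound 4. Compound 4 is thus estimated to give 92% in this assay, within 82% to 100%, most likely reported again as a limit.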

Compound 4, percent of the compound remaining: > 90%
Compound 4: a limit, no number (the forecaster's own chance of this, stated with the estimate: 70%); the middle value does not contradict the limit.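

No new step can be read between compound 3 and compound 4: in this assay both rest at a limit, so the exchange of 4-hydroxypiperidin-1-yl for amino on the carbonyl carbon has no readable size. The compounds shown leave open any ranking among them and which structural change would move the percent remaining off the shared limit: the limit of > 90% in this assay, at which 4 of the 4 values shown sit.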